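The source may hold more compounds than are shown below. What is called first, only, known or untested is meant among the compounds shown, and "the series" means these compounds.

Measured compounds: compound 1 `O=C(N/N=C/c1ccc(Br)cc1)c1cnccn1`, 100%; compound 2 `COc1ccc(/C=N/NC(=O)c2cnccn2)cc1`, 55%.

Within the data shown here, in an ADME assay on J774 cells (Mus musculus) for cytotoxicity, read by MTT assay, with a stated time of 48 h, tested at 100 ug/mL (on this read-out higher numbers stand for a weaker effect at the one concentration tested and lower numbers for a stronger effect), compound 2 gives the lowest of the two numbers, with compound 1 giving 100% as the only neighbour. Among the measured compounds shown here, the single measured step, a number 45 percentage points lower from compound 1 to compound 2 (beyond the scatter), lies beyond the scatter. Compound 3 `N#Cc1ccc(/C=N/NC(=O)c2cnccn2)cc1` differs from compound 2 by cyano in place of methoxy on an aromatic carbon. For the measured compounds named here, no measured step involves cyano, so nothing directly bears on this change; the one step shows only that swapping the group at that aromatic carbon can shift the number a great deal. The expected step is therefore uncertain in direction, a number 20 percentage points higher from compound 2 to compound 3 (beyond the scatter). For compound 3 the estimate in this assay is 75%, with a range from 40% to 100%.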

Compound 3, a percentage reported as activity, at one concentration (the size of the read-out at that concentration, not a potency): 100%
Estimate against measurement, compound 3: 25 percentage points below; the measured number falls inside the stated range.
By their numbers in this assay, from the lowest: compound 2; then compounds 1 and 3 (each within the scatter of the next).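

In this assay, cyano in place of methoxy gives a number 45 percentage points higher from compound 2 to compound 3 (beyond the scatter) and cyano in place of bromo gives no change at the digits printed from compound 1 to compound 3 (within the scatter). Among these three groups on the aromatic carbon, only methoxy therefore stands apart, while bromo and cyano cannot be told apart on this read-out. The data offer no explanation for this difference.

As far as these compounds go, it remains open whether the lower number is specific to methoxy or also appears with an amine, a hydroxyl or a longer alkoxy chain. From the compounds shown here alone, the effect of a carboxylic acid at this place also remains unknown.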